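The source may report more compounds than this note shows. Statements on the series, on what has been measured and on what is new or still open speak of the compounds shown alone.

Within the data shown here, in a functional assay on HEK293 cells for agonist activity at D(4) dopamine receptor (Homo sapiens), read by FLIPR (a higher number here means that more compound is needed for the effect, a lower number that less compound is needed), compound 2 `Cc1cccc(NC(=O)CN2CCC(c3ccccc3)CC2)c1` gives 170 nM, the highest of the two numbers measured so far; compound 1 `Cc1cccc(NC(=O)CN2CCC(c3cccc(O)c3)CC2)c1` gives 8 nM. Among the measured compounds shown here, the only step known is a 21-fold higher number from compound 1 to compound 2 (1.33 log units; beyond the scatter), and it concerns hydroxy, not fluoro, so it bears on compound 3 `Cc1cccc(NC(=O)CN2CCC(c3cccc(F)c3)CC2)c1` only loosely. Change: fluoro in place of hydrogen on an aromatic carbon. For the measured compounds named here, no measured pair shows fluoro entering, and a single heavy atom without donor or acceptor gives no clear direction to expect. The step of a 1.4-fold lower number from compound 2 to compound 3 (0.15 log units; within the scatter) is therefore expected to stay within the scatter. Estimate for compound 3 in this assay: 120 nM, range 40 nM to 400 nM.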

Compound 3, half-maximal effective concentration: 512 nM
The estimate for compound 3 lay 4.3-fold (0.63 log units) below the measured number; the measured number lies above the stated range.
By their numbers in this assay, from the lowest: compound 1; then compound 2; then compound 3.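

In this assay, fluoro in this place is not a silent replacement for hydrogen: the change gives a 3.0-fold higher number from compound 2 to compound 3 (0.48 log units; beyond the scatter). Against hydroxy in the same place, fluoro gives a 64-fold higher number from compound 1 to compound 3 (1.81 log units; beyond the scatter), so fluoro and hydroxy move the number in opposite directions from hydrogen, and of the three only hydroxy lowers it. No measurement here bears on the reason for this order.

On these data alone, whether an amine or a methoxy group in this place would lower the number as hydroxy does remains open. So does whether fluoro elsewhere on the ring would raise it.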